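Nitro in place of bromo on the benzyl ring

A few compounds are considered here, and "the series" means these few. Any claim that something is new, unique, unknown or untested is made for them only; others in the source may bear on it.

Compound 3 `OCc1cn(Cc2cccc(Br)c2)c2ccccc12` carries a bromo group on the benzyl ring. In a functional assay on NCI-H460 cells (Homo sapiens) for cytotoxicity, read by sulforhodamine B assay, with a stated time of 3 days (on this read-out higher numbers stand for weaker inhibition and lower numbers for stronger inhibition), compound 3 gives 28 nM, the second highest of three numbers; compound 2 `OCc1cn(Cc2cccc(Cl)c2)c2ccccc12` gives 19 nM and compound 1 `OCc1cn(Cc2ccccc2)c2ccccc12` gives 112 nM. The steps of a 4.0-fold lower number from compound 1 to compound 3 (0.60 log units; beyond the scatter) and a 5.9-fold lower number from compound 1 to compound 2 (0.77 log units; beyond the scatter) were modest and beyond the scatter, whereas a 1.5-fold higher number from compound 2 to compound 3 (0.17 log units; within the scatter) lay within it. Compound 4 `O=[N+]([O-])c1cccc(Cn2cc(CO)c3ccccc32)c1` differs from compound 3 by nitro in place of bromo on an aromatic carbon, placed meta to a large group. Within the data shown here, no measured step involves a nitro group, so only the two halogen steps from compound 1 bear on it, both modest. A small shift, or none beyond the scatter, is therefore expected. The estimate for compound 4 in this assay is 40 nM, with a range from 12 nM to 130 nM. This expected estimate means a 1.4-fold higher number from compound 3 to compound 4 (0.15 log units; within the scatter).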

Compound 4, half-maximal inhibitory concentration: 39 nM
Compound 4: middle estimate off by 1.0-fold (0.01 log units), on the high side; low and high end bracket the measured number.
By their numbers in this assay, from the lowest: compounds 2, 3 and 4 (each within the scatter of the next, the first and the last beyond it); then compound 1.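

In this assay, a non-halogen group at this place also keeps a lower number than the unsubstituted compound, with a 2.9-fold lower number from compound 1 to compound 4 (0.46 log units; beyond the scatter) beyond the scatter. Nitro and bromo cannot be told apart, with a 1.4-fold higher number from compound 3 to compound 4 (0.14 log units; within the scatter) within the scatter, whereas a 2.1-fold higher number from compound 2 to compound 4 (0.31 log units; beyond the scatter) lies beyond it, so nitro and chloro can be separated. Nothing available explains these differences. Open, as far as these compounds go, is whether an amine or a carboxylic acid at this place would also keep a lower number than compound 1.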